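A Bulkier Alkyl Group on the Aryl Ring

A few compounds are considered here, and "the series" means these few. Any claim that something is new, unique, unknown or untested is made for them only; others in the source may bear on it.

Of the compounds shown here, three that share one core have been tested in a functional assay on MCF7 cells (Homo sapiens) for antiproliferative activity, read by MTT assay, with a stated time of 96 h; a lower number here means a stronger inhibitor, a higher number a weaker inhibitor. Compound 2 `O=C1C2=C(C(=O)c3ncccc31)C1(CS2)NC(=O)N(c2ccccc2)C1=O` carries an unsubstituted phenyl ring and gives 1 nM. Compound 1 `O=C1C2=C(C(=O)c3ncccc31)C1(CS2)NC(=O)N(c2ccc([N+](=O)[O-])cc2)C1=O` carries a nitro group on that ring and gives 350 nM. Compound 3 `CCc1ccc(N2C(=O)NC3(CSC4=C3C(=O)c3ncccc3C4=O)C2=O)cc1` carries an ethyl group instead and gives 50 nM, which puts compound 3 second highest of the three numbers: the change from compound 1 reads a 7.0-fold lower number from compound 1 to compound 3 (0.85 log units; beyond the scatter), while the change from compound 2 reads a 50-fold higher number from compound 2 to compound 3 (1.70 log units; beyond the scatter).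

Compound 4 `CC(C)(C)c1ccc(N2C(=O)NC3(CSC4=C3C(=O)c3ncccc3C4=O)C2=O)cc1` differs from compound 3 in one place: tert-butyl in place of ethyl on an aromatic carbon. For the measured compounds named here, no measured step covers ethyl against tert-butyl directly. The step that bears most on it is a 50-fold higher number from compound 2 to compound 3 (1.70 log units; beyond the scatter), which shows that putting ethyl on that aromatic carbon in place of hydrogen raised the number by a large amount. Tert-butyl is the larger group of the two, so a further rise, though probably a more modest one, is expected. Compound 4 is therefore estimated at 150 nM, with a range from 30 nM to 800 nM. This estimate means an expected step of a 3.0-fold higher number from compound 3 to compound 4 (0.48 log units; beyond the scatter).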

Compound 4, half-maximal inhibitory concentration: 130 nM
The estimate for compound 4 lay 1.2-fold (0.06 log units) above the measured number, and the stated range covers the measured number.
By their numbers in this assay, from the lowest: compound 2; then compound 3; then compound 4; then compound 1.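

With compound 4, this position on the aryl ring now has a three-member alkyl series in this assay, and the number climbs at each stage: a 50-fold higher number from compound 2 to compound 3 (1.70 log units; beyond the scatter), then a 2.6-fold higher number from compound 3 to compound 4 (0.41 log units; beyond the scatter), for a total of a 130-fold higher number from compound 2 to compound 4 (2.11 log units; beyond the scatter). The second stage is much smaller than the first, so most of the loss comes with the first alkyl group, and enlarging ethyl to tert-butyl adds only a modest further rise. Nitro goes against any simple reading of the series, since tert-butyl still improves on it, with a 2.7-fold lower number from compound 1 to compound 4 (0.43 log units; beyond the scatter), and compound 1 keeps the highest number of the four; no measurement among those shown accounts for these differences.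

On these data alone, it remains open whether methyl would already cost as much as ethyl, and whether a longer chain such as n-butyl would continue the upward trend seen with ethyl and tert-butyl. An amine or a carboxylic acid at this same position could also behave quite differently from both the alkyl groups and nitro, so the series says little about groups of those kinds.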